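The compounds below may be only part of what the source reports. "The series", "measured", "known", "first", "only" and "open" are said of these compounds alone.

Compound 1 `Cc1oc(-c2ccc(Cl)cc2)nc1CN1CCC(C(=O)NCCCN2C[C@H](C)C[C@H](C)C2)CC1`: > 72 ug/mL
Compound 2 `Cc1ccccc1-c1nc(CN2CCC(C(=O)NCCCN3CCCC(CC(C)C)C3)CC2)c(C)o1`: 54.9 ug/mL
Compound 3 `Cc1cccc(Cl)c1-c1nc(CN2CCC(C(=O)NCCCN3CCC(C)(C)CC3)CC2)c(C)o1`: > 74 ug/mL

In a physicochemical assay for solubility, in phosphate buffer, measured as kinetic solubility, at pH 7.4 (on this read-out lower numbers stand for lower solubility and higher numbers for higher solubility), compound 1 reads > 72 ug/mL, which is a limit and not a number. Compound 3 reads > 74 ug/mL, which is also a limit. Compound 4 `Cc1oc(-c2c(Cl)cccc2C(F)(F)F)nc1CN1CCC(C(=O)NCCCN2C[C@H](C)C[C@H](C)C2)CC1` keeps the core of compound 1, with 2-chloro-6-(trifluoromethyl)phenyl in place of 4-chlorophenyl on an aromatic carbon. Among the measured compounds shown here, no measured pair shows this change. For the measured compounds named here, the expectation therefore leans on compound 2 at 54.9 ug/mL, the only reading in this assay that is a number. The expected step is an at least 1.2-fold lower number from compound 1 to compound 4 (0.07 log units; that floor lies within the scatter), a modest fall that may stay within the scatter. For compound 4 the estimated value is 60 ug/mL, with an expected range of 25 ug/mL to 90 ug/mL.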

Compound 4, solubility: 65.1 ug/mL
The estimate for compound 4 lay 1.1-fold (0.04 log units) below the measured number; low and high end bracket the measured number.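

Among the compounds shown here, on the core of compound 1, putting 2-chloro-6-(trifluoromethyl)phenyl in place of 4-chlorophenyl gives the first step at this position that can be followed in this assay: an at least 1.1-fold lower number from compound 1 to compound 4 (0.04 log units; that floor lies within the scatter). The step has only a floor, and its true size cannot be told because compound 1 stands at a limit: the limit of > 72 ug/mL in this assay, at which 1 of the 4 values shown sits.

The compounds shown leave open how a phenyl carrying only chlorine at one of these places, or only trifluoromethyl, would read. They also leave open how a phenyl bearing an amine or a carboxylic acid would read here.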